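A few compounds are considered here, and "the series" means these few. Any claim that something is new, unique, unknown or untested is made for them only; others in the source may bear on it.

Three compounds share one core and differ only in the group on an amine nitrogen in a ring: compound 1 `Nc1scc(CN2CCN(c3cccc(Cl)c3Cl)CC2)c1C(=O)c1ccc(Cl)cc1`, compound 2 `Nc1scc(CN2CCN(c3cccc(C(F)(F)F)c3)CC2)c1C(=O)c1ccc(Cl)cc1` and compound 3 `Nc1scc(CN2CCN(c3ccc(F)c(F)c3)CC2)c1C(=O)c1ccc(Cl)cc1`. In a functional assay on CHO cells with adenosine receptor A1 (Homo sapiens) as the target, read by cAMP accumulation and immunoassay, with a stated time of 6 min, tested at 0.01 uM (a higher number here means a weaker effect of the compound at the concentration tested, a lower number a stronger effect), compound 1 gives 1%, compound 2 gives -8.2% and compound 3 gives -3.2%. Among these three numbers compound 3 sits in the middle, yet its separations from both neighbours are small: the step of a number 4.2 percentage points lower from compound 1 to compound 3 (within the scatter) and the step of a number 5 percentage points higher from compound 2 to compound 3 (within the scatter) each lie within the scatter, as does a number 9.2 percentage points lower from compound 1 to compound 2 (within the scatter).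

Compound 4 `Nc1scc(CN2CCN(CCCc3ccc(Cl)cc3)CC2)c1C(=O)c1ccc(Cl)cc1` follows from compound 3 by the change (3-(4-chlorophenyl)propyl in place of 3,4-difluorophenyl on an amine nitrogen in a ring). All three measured steps swap one substituted phenyl for another on that ring nitrogen and none moves the read-out beyond the scatter. Going by the values given here, the change to compound 4 is of a different kind, since a chain now carries the aromatic ring, and no measured pair covers such a change. With every measured step flat, the plain expectation is no step beyond the scatter, though the untested kind of change widens the uncertainty. Compound 4 is therefore expected to give about -2%, between -16% and 12%, which means an estimated step of a number 1.2 percentage points higher from compound 3 to compound 4 (within the scatter).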

Compound 4, a percentage reported as activity, at one concentration (the size of the read-out at that concentration, not a potency): 0%
Estimate against measurement, compound 4: 2 percentage points below, and the stated range covers the measured number.
By their numbers in this assay, from the lowest: compounds 2, 3, 4 and 1 (each within the scatter of the next).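

In this assay, moving the aromatic ring onto a chain as 3-(4-chlorophenyl)propyl leaves the read-out flat, with a number 3.2 percentage points higher from compound 3 to compound 4 (within the scatter), a number 8.2 percentage points higher from compound 2 to compound 4 (within the scatter) and a number 1 percentage points lower from compound 1 to compound 4 (within the scatter). The insensitivity seen at this ring nitrogen therefore now reaches beyond swaps of one substituted phenyl for another to a group of a different kind, and none of the four compounds stands apart from the others. Nothing available explains this flatness.

The compounds shown leave open whether a shorter link such as benzyl, an unsubstituted phenyl, or a chain ending in an amine or a carboxylic acid would move the number beyond the scatter on this ring nitrogen. All four numbers also come from one tested concentration, so they give no potency and cannot show whether these groups differ at other concentrations, and every change shown lies at this one nitrogen, leaving the effect of changes elsewhere on the shared core unknown.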